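Amine Ring Contraction on the Shared Core

The compounds below may be only part of what the source reports. "The series", "measured", "known", "first", "only" and "open" are said of these compounds alone.

The measured compounds:
compound 1, `COc1cc(OC)c2c(=O)cc(-c3ccccc3Cl)oc2c1CN1CCCCC1`: 15500 nM
compound 2, `CCN(CC)Cc1c(OC)cc(OC)c(C(=O)/C=C/c2ccccc2Cl)c1O`: 4200 nM
compound 3, `COc1cc(OC)c(C(=O)/C=C/c2ccccc2Cl)c(O)c1CN1CCCCC1`: 1700 nM
compound 4, `COc1cc(OC)c(C(=O)/C=C/c2ccccc2Cl)c(O)c1CN1CCCC1`: not yet measured

In a functional assay on PC-3 cells (Homo sapiens) for antiproliferative activity, with a stated time of 72 h (on this read-out higher numbers stand for weaker inhibition and lower numbers for stronger inhibition), compound 3 gives 1700 nM, the lowest of the three numbers; compound 2 gives 4200 nM and compound 1 gives 15500 nM. The next compound changes only the amine: pyrrolidin-1-yl in place of piperidin-1-yl on a saturated chain carbon bound to an aromatic carbon. Among the measured compounds shown here, the one measured step that bears on this place is a 2.5-fold lower number from compound 2 to compound 3 (0.39 log units; beyond the scatter), a modest gain when the amine was changed on the same carbon. Since compound 4 keeps a cyclic amine and only the ring shrinks, a step smaller than that one is expected, probably within the scatter. Compound 4 is therefore estimated at 1700 nM in this assay, with a range of 700 nM to 4500 nM, meaning an expected step of no change at the digits printed from compound 3 to compound 4 (within the scatter).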

Compound 4, half-maximal inhibitory concentration: 3100 nM
Compound 4: middle estimate off by 1.8-fold (0.26 log units), on the low side; the range from low to high includes it.
By their numbers in this assay, from the lowest: compounds 3, 4 and 2 (each within the scatter of the next, the first and the last beyond it); then compound 1.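

In this assay, shrinking the cyclic amine on a saturated chain carbon bound to an aromatic carbon gives a 1.8-fold higher number from compound 3 to compound 4 (0.26 log units; within the scatter), so piperidin-1-yl and pyrrolidin-1-yl cannot be told apart here. Pyrrolidin-1-yl in place of diethylamino gives a 1.4-fold lower number from compound 2 to compound 4 (0.13 log units; within the scatter), so compound 4 separates from neither neighbour, while the earlier step of a 2.5-fold lower number from compound 2 to compound 3 (0.39 log units; beyond the scatter) stays the only one beyond the scatter at this place. No available evidence explains these steps. Open, as far as these compounds go, is whether morpholin-4-yl or dimethylamino on that carbon would read differently, and whether pyrrolidin-1-yl on the core of compound 1 would behave alike.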